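Swapping the Benzyl Group: From Compound 1 to Compound 4

The source may report more compounds than this note shows. Statements on the series, on what has been measured and on what is new or still open speak of the compounds shown alone.

Compound 1 `CCCn1c(=O)c2nc(-c3cnn(Cc4cccc(C)c4)c3)[nH]c2n(CCC)c1=O` is the reference point. In an in vitro assay on HEK293 cells for displacement of a labelled ligand from adenosine receptor A2b (Homo sapiens) (a lower number here means a stronger inhibitor, a higher number a weaker inhibitor), compound 1 gives 36 nM, the lowest of the two numbers recorded. Compound 3 `CC(C)Cn1c(=O)c2nc(-c3cnn(Cc4cccc(C(F)(F)F)c4)c3)[nH]c2n(CC(C)C)c1=O` gives 300 nM in this assay, a gap from compound 1 that lies beyond the usual scatter. Compound 2 `CCCn1c(=O)c2c(nc(-n3cc(I)cn3)n2Cc2ccccc2)n(CCC)c1=O` reaches only a limit of the assay, > 5800 nM, sitting at the limit of > 5800 nM in this assay, at which 1 of the 3 values shown sits. Compound 4 `CCCn1c(=O)c2nc(-c3cnn(Cc4ccc(F)cc4F)c3)[nH]c2n(CCC)c1=O` has not yet been measured. It differs from compound 1 in one place: 2,4-difluorophenyl in place of 3-methylphenyl on a saturated chain carbon bound to an aromatic nitrogen. Among the compounds with values here, no measured pair shows this exact change, so its size is uncertain. A modest step is expected, a 1.7-fold higher number from compound 1 to compound 4 (0.22 log units; within the scatter), with the direction open and possibly within the scatter. Compound 4 is therefore estimated at 60 nM, within a range from 15 nM to 250 nM.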

Compound 4, inhibition constant: 700 nM
Compound 4: middle estimate off by 12-fold (1.07 log units), on the low side, and the stated range ends below it.
By their numbers in this assay, from the lowest: compound 1; then compound 3; then compound 4. At a limit, above all of these: compound 2.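

Replacing 3-methylbenzyl with 2,4-difluorobenzyl is far from a neutral swap at this position, on a saturated chain carbon bound to an aromatic nitrogen (a 19-fold higher number from compound 1 to compound 4 (1.29 log units; beyond the scatter)). The sensitivity appears even though both groups hold one six-membered aromatic ring of carbon only and neither has hydrogen-bond donors or acceptors. Nothing shown here accounts for the size of this step.

As far as these compounds go, the change removes the methyl and adds two fluorines at once, so which of these matters most stays open. Plain benzyl, 3-fluorobenzyl or 4-fluorobenzyl on the same core could help separate them.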